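Swapping the benzyl substituent on a shared amide core

This account rests on a few compounds, and the source may have more. Where it says the series, first, only, none or still open, it means among the compounds named here.

On these data alone, the piece follows three measured compounds and one still open. Compound 1 `COc1ccc(CN(C(=O)CSc2nc3ccccc3s2)c2cc(OC)c(OC)c(OC)c2)cc1N=[N+]=[N-]` gives 187 nM in a functional assay on MGC-803 cells (Homo sapiens) for antiproliferative activity, read by MTT assay, with a stated time of 48 h (on this read-out lower numbers stand for stronger inhibition and higher numbers for weaker inhibition), the higher of the two numbers available; its nearest neighbour is compound 2 `COc1ccc(CN(C(=O)CSc2nc3ccccc3s2)c2cc(OC)c(OC)c(OC)c2)cc1`, which gives 163 nM, a difference of a 1.1-fold lower number from compound 1 to compound 2 (0.06 log units; within the scatter) that follows from hydrogen in place of azido on an aromatic carbon. Compound 3 `COc1cc(N(Cc2ccc(Cl)cc2)C(=O)CSc2nc3ccccc3s2)cc(OC)c1OC` reaches only the limit of the assay, > 80000 nM, and is not a number. The step from compound 1 to compound 3 is an at least 420-fold higher number from compound 1 to compound 3 (2.63 log units; beyond the scatter), and that from compound 2 to compound 3 is an at least 490-fold higher number from compound 2 to compound 3 (2.69 log units; beyond the scatter), the latter resting on chloro in place of methoxy on an aromatic carbon.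

Compound 4 `COc1cc(N(Cc2ccc(F)cc2)C(=O)CSc2nc3ccccc3s2)cc(OC)c1OC` has not yet been measured. It differs from compound 1 by 4-fluorophenyl in place of 3-azido-4-methoxyphenyl on a saturated chain carbon bound to an amide-type nitrogen. The measured steps that bear on this change are the two large losses toward compound 3, where a halogen on the benzyl ring took the place of methoxy, both limited by the limit of > 80000 nM in this assay, at which 1 of the 3 values shown sits. A large step in the same direction is therefore expected, and compound 4 is estimated at 30000 nM, within 3000 nM to 100000 nM, which amounts to an expected step of a 160-fold higher number from compound 1 to compound 4 (2.21 log units; beyond the scatter).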

Compound 4, half-maximal inhibitory concentration: > 80000 nM
Compound 4 ended at the assay's limit; the forecaster's own chance of this, stated with the estimate: 50%; at least 2.6-fold (0.42 log units) between middle value and limit.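

In this assay, the loss seen with chloro in compound 3 returns with fluoro on the same benzyl ring, on the saturated chain carbon bound to an amide-type nitrogen: an at least 420-fold higher number from compound 1 to compound 4 (2.63 log units; beyond the scatter), and an at least 490-fold higher number from compound 2 to compound 4 (2.69 log units; beyond the scatter). The large drop is therefore not tied to chloro alone, since among the four compounds shown, the two with a halogen in place of methoxy, compound 3 and compound 4, both end far from the two that keep the methoxy, compound 1 and compound 2, and none goes against this. Compound 3 and compound 4 each stand at a limit and not at a number, so the step between them cannot be read and the two halogens cannot be ranked: the limit of > 80000 nM in this assay, at which 2 of the 4 values shown sit.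

On these data alone, whether a hydroxyl, an amine or a methyl group in place of the methoxy would stay with compound 2 or fall with compound 3 and compound 4 remains open. As far as these compounds go, it is also open whether the methoxy alone is enough, as a halogen kept together with the methoxy on the same ring would show.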